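Thiazolyl Urea Replaces Dimethylphenyl on a Shared Core

The source may hold more compounds than are shown below. What is called first, only, known or untested is meant among the compounds shown, and "the series" means these compounds.

Compound 2 `Cc1cc(C)cc(NC(=O)Nc2ccc(Nc3ncnc4c3OCCN4)cc2)c1` bears a urea on the shared core. In a functional assay on BaF3 cells (Mus musculus) for inhibition, read by MTT assay, with a stated time of 3 days (a higher number here means a weaker inhibitor of growth, a lower number a stronger inhibitor of growth), compound 2 gives only a limit, > 10000 nM. Compound 1 `O=C(Nc1ccc(Cl)cc1)Nc1ccc(Nc2ncnc3c2OCCN3)cc1` likewise stands at a limit, giving > 10000 nM in this assay. The step that the two limits leave unreadable from compound 1 to compound 2 cannot be read, since (the limit of > 10000 nM in this assay, at which 2 of the 2 values shown sit). Compound 3 `CC(C)(C)c1csc(NC(=O)Nc2ccc(Nc3ncnc4c3OCCN4)cc2)n1` differs from compound 2 by 4-(tert-butyl)-1,3-thiazol-2-yl in place of 3,5-dimethylphenyl on an amide-type nitrogen. Among the compounds with values here, no measured step bears on this change, and both known values are limits, so no direction beyond the scatter can be drawn. Compound 3 is expected to give 10000 nM, within 3000 nM to 30000 nM. For compound 3 the estimated step is a number no higher from compound 2 to compound 3 (the limit leaves the size open).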

Compound 3, concentration for 50% growth inhibition: > 10000 nM
Compound 3 was reported as a limit; the forecaster's own chance of this, stated with the estimate: 75%; the middle value sits exactly at the limit.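

No new step can be read among compound 1, compound 2 and compound 3, since all three stand at a limit in this assay: the limit of > 10000 nM in this assay, at which 3 of the 3 values shown sit. The compounds shown leave open which group on the amide-type nitrogen, if any, would give a readable value in this assay on this shared core.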